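Compound 3 to compound 4: a step from the limit

The compounds below may be only part of what the source reports. "The series", "measured", "known", "first", "only" and "open" are said of these compounds alone.

Measured in an ADME assay on Karpas-1106P cells (Homo sapiens) for cytotoxicity; a lower number here means that less compound is needed, a higher number that more compound is needed for the effect:
- compound 1 `Cc1ccc(S(=O)(=O)N[C@@H](CC(=O)NC(C)(C)C)C(=O)NCCNC(=O)c2ccccc2F)cc1`: > 11100 nM
- compound 2 `Cc1ccc(S(=O)(=O)N[C@@H](CC(=O)NC(C)(C)C)C(=O)NCCNC(=O)NCc2ccccc2)cc1`: > 11100 nM
- compound 3 `Cc1ccc(S(=O)(=O)N[C@@H](CC(=O)NC(C)(C)C)C(=O)NCCNC(=O)c2cc(C)ccn2)cc1`: > 11100 nM

Each of these entries is a limit and not a number. In this assay compound 3 gives > 11100 nM, and it stands with compound 1 and compound 2 at the limit of > 11100 nM in this assay, at which 3 of the 3 values shown sit.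

Compound 4 `C#Cc1cccc(C(=O)NCCNC(=O)[C@H](CC(=O)NC(C)(C)C)NS(=O)(=O)c2ccc(C)cc2)c1` differs from compound 3 in one place: 3-ethynylphenyl in place of 4-methylpyridin-2-yl on a carbonyl carbon. Two measured steps changed the group on the same carbonyl carbon: a step that the two limits leave unreadable from compound 1 to compound 3 and a step that the two limits leave unreadable from compound 2 to compound 3. Neither gives a size, and neither involves 3-ethynylphenyl. With no readable step to build on, no step beyond the scatter is expected in this assay, and no direction can be assigned. The most likely outcome is another limit.

The expected change is a step that the limit leaves unreadable from compound 3 to compound 4. The estimate for compound 4 is 15000 nM, with an expected range from 6000 nM to 30000 nM.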

Compound 4, half-maximal effective concentration: > 11100 nM
Compound 4 was reported as a limit (the forecaster's own chance of this, stated with the estimate: 75%); the middle value is on the limit's open side.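

In this assay compound 4 gives > 11100 nM, a limit and not a number, so the steps to it from compound 1, compound 2 and compound 3 cannot be read: the limit of > 11100 nM in this assay, at which 4 of the 4 values shown sit. The compounds shown leave open whether any group on this carbonyl carbon gives a measurable value, and how these four compounds rank.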